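From dimethylamino to 4-methylpiperazin-1-yl in a cell toxicity test

The source may hold more compounds than are shown below. What is called first, only, known or untested is meant among the compounds shown, and "the series" means these compounds.

In a toxicity assay on J774.A1 cells (Mus musculus) for cytotoxicity, read by SYBR Green assay, with a stated time of 1 h (on this read-out higher numbers stand for an effect only at larger amounts of compound and lower numbers for an effect already at smaller amounts), compound 1 `CN(C)c1ccc2cc(-c3ccc(Cl)cc3Cl)c(N)nc2c1` gives 8700 nM and compound 2 `CN(C)c1ccc2cc(-c3cn(C)c4ccccc34)c(N)nc2c1` gives 3700 nM as the lower of the two numbers, a gap beyond the usual scatter. Compound 3 `CN1CCN(c2ccc3cc(-c4cn(C)c5ccccc45)c(N)nc3c2)CC1` carries 4-methylpiperazin-1-yl in place of dimethylamino on an aromatic carbon and has not been measured yet. Among the measured compounds shown here, no measured pair of compounds shows such a swap. The expected step of a 1.1-fold lower number from compound 2 to compound 3 (0.02 log units; within the scatter) in this assay is small and stays within the scatter. For compound 3 the estimated value is 3500 nM with 1400 nM to 9000 nM as the likely span.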

Compound 3, half-maximal effective concentration: 1000 nM
The estimate for compound 3 lay 3.5-fold (0.54 log units) above the measured number; the whole stated range lies above it.
By their numbers in this assay, from the lowest: compound 3; then compound 2; then compound 1.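

This position responds to what it carries: in this assay, 4-methylpiperazin-1-yl in place of dimethylamino on an aromatic carbon gives a 3.7-fold lower number from compound 2 to compound 3 (0.57 log units; beyond the scatter), so the cells are affected at smaller amounts of compound. Compound 1 and compound 2 both carry dimethylamino here, so neither could show this. No measurement shown here explains the step.

From the compounds shown here alone, it remains open whether the ring or its second nitrogen matters, which a piperidine or morpholine ring here could help separate. The same swap on compound 1 also remains untested in the compounds shown.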